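A Pyrimidinyl Amine in Place of the Benzamide

A few compounds are considered here, and "the series" means these few. Any claim that something is new, unique, unknown or untested is made for them only; others in the source may bear on it.

compound 1, `C[C@@H](Cn1ccc(-c2ccc(C#N)c(Cl)c2)n1)NC(=O)c1ccccc1`: 1830 nM
compound 2, `C[C@@H](Cn1ccc(-c2ccc(C#N)c(Cl)c2)n1)NC(=O)c1cccc(OCC(O)CO)c1`: 740 nM
compound 3, `C[C@@H](Cn1ccc(-c2cc(F)c(C#N)c(Cl)c2)n1)NC(=O)Nc1cc(C(C)(C)C)[nH]n1`: 1630 nM

Among the compounds with values here, in a functional assay on LNCaP cells (Homo sapiens) for antiproliferative activity, read by CCK-8 assay, with a stated time of 6 days (a lower number here means a stronger inhibitor, a higher number a weaker inhibitor), compound 1 gives the highest of the three numbers; compound 3 lies within the scatter of it, and the only step beyond the scatter is a 2.5-fold lower number from compound 1 to compound 2 (0.39 log units; beyond the scatter). Compound 4, `C[C@@H](Cn1ccc(-c2ccc(C#N)c(Cl)c2)n1)Nc1cncnc1`, differs from compound 1 in one place: pyrimidin-5-yl in place of benzoyl on an amine nitrogen. No measured step touches that place; the one step seen, a 2.5-fold lower number from compound 1 to compound 2 (0.39 log units; beyond the scatter), alters an aromatic carbon elsewhere on the shared core, so nothing shown anticipates the size or direction of this move. The estimate therefore stays near the starting point with a wide range. Compound 4 is expected to give 2000 nM, between 500 nM and 8000 nM, an expected step of a 1.1-fold higher number from compound 1 to compound 4 (0.04 log units; within the scatter).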

Compound 4, half-maximal inhibitory concentration: 2070 nM
For compound 4 the middle estimate is 1.0-fold (0.01 log units) below the measured one; the measured number falls inside the stated range.
By their numbers in this assay, from the lowest: compound 2; then compounds 3, 1 and 4 (each within the scatter of the next).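

In this assay, pyrimidin-5-yl in place of benzoyl on the amine nitrogen gives a 1.1-fold higher number from compound 1 to compound 4 (0.05 log units; within the scatter). Within the data shown here, this position, which no earlier step touched, therefore accepts a ring attached directly to the amine nitrogen, with no carbonyl, and the number stays within the scatter. No measured property in the material shown bears on this result.

Still open, from the compounds shown here alone, is whether the 2,3-dihydroxypropoxy group of compound 2 would lower the number on the pyrimidin-5-yl ring as it did on the benzoyl ring. A pyridin-3-yl ring or an added amine on the pyrimidine at this position also remains untested in the compounds shown.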